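The compounds below may be only part of what the source reports. "The series", "measured", "known", "first", "only" and "open" are said of these compounds alone.

Compound 1 `O=S(=O)(NCCCNCc1cccc2ccccc12)c1cc(C(F)(F)F)cc(C(F)(F)F)c1` was tested in a functional assay on Capan-2 cells (Homo sapiens) for inhibition, read by MTT assay, with a stated time of 72 h (on this read-out lower numbers stand for stronger inhibition of growth and higher numbers for weaker inhibition of growth), where compound 1 gives 2700 nM. Its closest measured relative is compound 2 `O=S(=O)(NCCCNCc1ccc(Cl)cc1)c1cc(C(F)(F)F)cc(C(F)(F)F)c1`, which in this assay gives 2700 nM. Compound 1 therefore stands level with compound 2 at the digits shown, and the step of no change at the digits printed from compound 1 to compound 2 (within the scatter) records no change within the scatter when 4-chlorophenyl replaces naphthalen-1-yl on a saturated chain carbon bound to an amine nitrogen.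

The unmeasured compound 3 `COc1cccc(CNCCCNS(=O)(=O)c2cc(C(F)(F)F)cc(C(F)(F)F)c2)c1` alters compound 1 at the same place: 3-methoxyphenyl in place of naphthalen-1-yl on a saturated chain carbon bound to an amine nitrogen. Among the measured compounds shown here, only one measured step bears on this change, the step of no change at the digits printed from compound 1 to compound 2 (within the scatter), and it was flat. That step also replaced naphthalen-1-yl by a single six-membered aromatic ring of carbon only at this position, so the present change is expected to behave alike, with no step beyond the scatter in either direction in this assay.

For compound 3 the expected step is no change at the digits printed from compound 1 to compound 3 (within the scatter). Compound 3 is thus estimated to give 2700 nM in this assay, with a likely range from 1000 nM to 7000 nM.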

Compound 3, concentration for 50% growth inhibition: 6400 nM
Beside the measured number, compound 3's estimate is 2.4-fold (0.37 log units) below it; measured number inside the range.
By their numbers in this assay, from the lowest: compounds 1 and 2 (each within the scatter of the next); then compound 3.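

In this assay, the earlier pair had suggested that a single six-membered aromatic ring of carbon only could stand in for naphthalen-1-yl on a saturated chain carbon bound to an amine nitrogen, but 3-methoxyphenyl shows that this does not hold for every such ring: there is a 2.4-fold higher number from compound 1 to compound 3 (0.37 log units; beyond the scatter). The same modest separation appears against the 4-chlorophenyl group, with a 2.4-fold higher number from compound 2 to compound 3 (0.37 log units; beyond the scatter), so the position distinguishes between two single rings that carry different groups. The number of rings alone does not order these three compounds, since compound 1 with two rings and compound 2 with one stand level while compound 3, also with one ring, stands apart, and no evidence is available that accounts for this difference.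

The compounds shown leave open whether the shift follows the methoxy group itself or its place on the ring, a question that 4-methoxyphenyl and 3-chlorophenyl would help to separate. As far as these compounds go, it also remains open how a hydroxy group or a dimethylamino group on the same ring would read in this assay.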